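Compound 3 to compound 4: a 4-hydroxyphenyl exchange

The compounds below may be only part of what the source reports. "The series", "measured", "known", "first", "only" and "open" are said of these compounds alone.

Compound 1 `N#Cc1ccc(/C=C/S(=O)(=O)Cc2ccc(Nc3ncnc4ccccc34)cc2)cc1`: > 100000 nM
Compound 2 `O=S(=O)(/C=C/c1ccc(F)cc1Cl)Cc1ccc(Nc2ncnc3ccccc23)cc1`: 100000 nM
Compound 3 `O=S(=O)(/C=C/c1ccc(C(F)(F)F)cc1F)Cc1ccc(Nc2ncnc3ccccc23)cc1`: 100000 nM

In a functional assay on HT-29 cells (Homo sapiens) (on this read-out higher numbers stand for weaker inhibition of growth and lower numbers for stronger inhibition of growth), compound 3 gives 100000 nM, level with compound 2 at 100000 nM. Compound 1 gives > 100000 nM, which is a limit and not a number. Compound 4 `O=S(=O)(/C=C/c1ccc(O)cc1)Cc1ccc(Nc2ncnc3ccccc23)cc1` carries 4-hydroxyphenyl in place of 2-fluoro-4-(trifluoromethyl)phenyl on a double-bonded chain carbon bound to a double-bonded chain carbon. Within the data shown here, the only step of readable size is no change at the digits printed from compound 2 to compound 3 (within the scatter), while a number no higher from compound 1 to compound 2 (the limit leaves the size open) and a number no higher from compound 1 to compound 3 (the limit leaves the size open) leave their size open. None of these steps brings in 4-hydroxyphenyl. The expected step, a 1.7-fold lower number from compound 3 to compound 4 (0.22 log units; within the scatter), is therefore estimated to stay within the scatter, leaning to lower numbers. Compound 4 is estimated at 60000 nM, with an expected range of 12000 nM to 100000 nM.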

Compound 4, concentration for 50% growth inhibition: 2000 nM
The estimate for compound 4 lay 30-fold (1.48 log units) above the measured number; the whole stated range lies above it.
By their numbers in this assay, from the lowest: compound 4; then compounds 2 and 3 (each within the scatter of the next).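

In this assay, the position on a double-bonded chain carbon bound to a double-bonded chain carbon proves able to move the read-out, which the earlier exchanges there did not show: 4-hydroxyphenyl gives a 50-fold lower number from compound 3 to compound 4 (1.70 log units; beyond the scatter) and a 50-fold lower number from compound 2 to compound 4 (1.70 log units; beyond the scatter). Hydroxy in place of cyano on an aromatic carbon gives an at least 50-fold lower number from compound 1 to compound 4 (1.69 log units; beyond the scatter). The value of compound 1 is a limit, not a number: the limit of > 100000 nM in this assay, at which 1 of the 4 values shown sits.

The compounds shown leave open whether the hydroxy itself or the removal of the other substituents carries this step. A 4-methoxyphenyl or 4-aminophenyl group at this position would begin to separate the two.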